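Dimethylamino in Place of Hydrogen: Expected Inhibition of Compound 4

The source may hold more compounds than are shown below. What is called first, only, known or untested is meant among the compounds shown, and "the series" means these compounds.

Compound 1, `COc1ccc(C(=O)c2cc(/C=C/C(=O)NO)n(C)c2)cc1`, in an assay on isolated protein with histone deacetylase HD2 (Zea mays) as the target (a lower number here means a stronger inhibitor, a higher number a weaker inhibitor), gives 1740 nM.
Compound 2, `Cn1cc(C(=O)c2ccc(F)cc2)cc1/C=C/C(=O)NO`, in this assay gives 2290 nM.
Compound 3, `Cn1cc(C(=O)c2ccccc2)cc1/C=C/C(=O)NO`, in this assay gives 2290 nM.

Compound 3 stands level with compound 2 in this assay; together they hold the highest of the three numbers, and compound 1 lies nearest to them on the other side, with a 1.3-fold higher number from compound 1 to compound 3 (0.12 log units; within the scatter). The three compounds share one core and differ only in the group on an aromatic carbon of a six-membered aromatic ring of carbon only, para to a large group.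

Compound 4, `CN(C)c1ccc(C(=O)c2cc(/C=C/C(=O)NO)n(C)c2)cc1`, continues this series: dimethylamino in place of hydrogen on an aromatic carbon. For the measured compounds named here, the steps that bear on this change are a 1.3-fold higher number from compound 1 to compound 2 (0.12 log units; within the scatter), a 1.3-fold higher number from compound 1 to compound 3 (0.12 log units; within the scatter) and no change at the digits printed from compound 2 to compound 3 (within the scatter); each of them exchanges the group at the same place, and none of them moves the number beyond the scatter. The change from compound 3 to compound 4 is therefore expected to give a step of a 1.2-fold lower number from compound 3 to compound 4 (0.08 log units; within the scatter), with no confident direction. Compound 4 is accordingly estimated at 1900 nM in this assay, within a range from 900 nM to 4000 nM.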

Compound 4, inhibition constant: 1450 nM
Beside the measured number, compound 4's estimate is 1.3-fold (0.12 log units) above it; low and high end bracket the measured number.
By their numbers in this assay, from the lowest: compounds 4, 1, 2 and 3 (each within the scatter of the next).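

In this assay, for the compounds shown here, dimethylamino on an aromatic carbon para to a large group gives a 1.6-fold lower number from compound 3 to compound 4 (0.20 log units; within the scatter) and a 1.6-fold lower number from compound 2 to compound 4 (0.20 log units; within the scatter) and also a 1.2-fold lower number from compound 1 to compound 4 (0.08 log units; within the scatter) in a series that had so far carried only hydrogen, fluoro and methoxy at this place. The group that enters here is the largest of the four, with 3 heavy atoms and a nitrogen, yet its number cannot be told apart from those of the three earlier compounds, so the flat picture they gave now holds across four groups on the shared core. Nothing at hand bears on why the number stays within the scatter across these groups.

What the compounds shown leave open is whether any group at this place can move the number beyond the scatter, such as a primary amine, a carboxylic acid, a longer chain or a second ring. They also leave open whether dimethylamino would give a similar result on another carbon of the same ring, since all four compounds carry their group at this one place.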